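This account rests on a few compounds, and the source may have more. Where it says the series, first, only, none or still open, it means among the compounds named here.

Measured so far in a functional assay on A549 cells (Homo sapiens) for cytotoxicity, read by MTT assay; on this read-out lower numbers stand for stronger inhibition and higher numbers for weaker inhibition:

Compound 1 `CCOC(=O)C12C(=O)OCC=C1COC2c1ccccc1` gives > 1000000 nM, a limit of the assay.
Compound 2 `CCOC(=O)C12C(=O)OCC=C1COC2c1cccc(Cl)c1` gives 28400 nM.
Compound 3 `CCOC(=O)C12C(=O)OCC=C1COC2c1ccc(Cl)cc1` gives > 1000000 nM, a limit of the assay.

Compound 3 therefore has no number of its own; it sits at the limit of > 1000000 nM in this assay, at which 2 of the 3 values shown sit, the same limit as compound 1, while compound 2 alone gives a readable number in this assay. Within the set, compound 3 is one of the two members for which only the limit is known.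

Compound 4 `CCOC(=O)C12C(=O)OCC=C1COC2c1ccco1` differs from compound 3 in one place: furan-2-yl in place of 4-chlorophenyl on a saturated ring carbon. The measured steps that touch this ring carbon are the exchange of the aryl group, an at least 35-fold higher number from compound 2 to compound 3 (1.54 log units; beyond the scatter), and the two chloro insertions, an at least 35-fold lower number from compound 1 to compound 2 (1.54 log units; beyond the scatter) and a step that the two limits leave unreadable from compound 1 to compound 3. Two of them are large, so the choice of aryl group at this position clearly moves the read-out, but all three concern chloro on a phenyl ring and none concerns a furan. The direction of the present change cannot be read from them; since compound 3 already sits at the limit, any readable step would be a lower number. Compound 4 is expected to give 200000 nM (range 20000 nM to 1000000 nM), an expected step of an at least 5.0-fold lower number from compound 3 to compound 4 (0.69 log units; beyond the scatter), with a substantial chance that only the limit is reported again.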

Compound 4, half-maximal inhibitory concentration: > 1000000 nM
Compound 4: a limit, no number (the forecaster's own chance of this, stated with the estimate: 55%); at least 5.0-fold (0.69 log units) between middle value and limit.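

In this assay, furan-2-yl on the saturated ring carbon next to the ring oxygen gives no readable number, which places a five-membered aromatic ring with 1 hetero atom alongside phenyl and 4-chlorophenyl at a limit of the assay: the limit of > 1000000 nM in this assay, at which 3 of the 4 values shown sit.

Within the data shown here, the 3-chlorophenyl group remains the only group at this place with a readable number, and its exchange for furan-2-yl gives an at least 35-fold higher number from compound 2 to compound 4 (1.54 log units; beyond the scatter). The steps reaching compound 4 from compound 3 and from compound 1 join two limits and cannot be read, so the furan-2-yl, phenyl and 4-chlorophenyl groups cannot be ranked against one another.

On these data alone, whether the readable number of the series needs chloro itself or would also appear with another group in its place, such as 3-methoxyphenyl or 3-aminophenyl, stays open. Also open, as far as these compounds go, is how the read-out would respond at the other end of the shared core, for instance with a carboxylic acid or a primary amide in place of the ethoxycarbonyl group.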